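From compound 2 to compound 3: a methyl group leaves

The source may hold more compounds than are shown below. What is called first, only, known or untested is meant among the compounds shown, and "the series" means these compounds.

Compound 1 `CCCCc1cc2c(=O)c(C(=O)NCCO)c[nH]c2cc1OCCOc1ccccc1`: > 20000 nM
Compound 2 `CCCCc1cc2c(=O)c(Br)c(C)[nH]c2cc1OCCOc1ccccc1`: > 10000 nM

In an ADME assay on J774 cells (Mus musculus) for cytotoxicity (a higher number here means that more compound is needed for the effect, a lower number that less compound is needed), compound 2 gives > 10000 nM, which is a limit of the assay and not a number. Compound 1 gives > 20000 nM, and this too is a limit. Among the measured compounds shown here, neither compound therefore has a measured number, and no measured step shows what a change on the shared core does in this assay.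

Compound 3 `CCCCc1cc2c(=O)c(Br)c[nH]c2cc1OCCOc1ccccc1` differs from compound 2 at a single place: hydrogen in place of methyl on an aromatic carbon. Hydrogen stands in place of methyl on an aromatic carbon, next to the ring nitrogen and ortho to a bromo group.

With so little to go on, the expected step that the limit leaves unreadable from compound 2 to compound 3 is none beyond the usual scatter. For compound 3 the estimated value is 15000 nM, with an expected range from 5000 nM to 25000 nM.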

Compound 3, half-maximal effective concentration: 8070 nM
Estimate against measurement, compound 3: 1.9-fold (0.27 log units) above; low and high end bracket the measured number.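

Among the compounds shown here, compound 3 is the only one of the three compounds with a measured number in this assay, which gives this aromatic carbon next to the ring nitrogen its first bounded step: hydrogen in place of methyl gives an at least 1.2-fold lower number from compound 2 to compound 3 (0.09 log units; that floor lies within the scatter). That step is only a floor because compound 2 stands at a limit: the limit of > 10000 nM in this assay, at which 1 of the 3 values shown sits.

Bromo in place of (2-hydroxyethyl)carbamoyl on an aromatic carbon gives the one step that clears the scatter, an at least 2.4-fold lower number from compound 1 to compound 3 (0.39 log units; beyond the scatter).

As far as these compounds go, how large the true effect of removing the methyl group is remains open, and it may be no more than scatter. From the compounds shown here alone, what an amine or a carboxylic acid on this same carbon would do in this assay also remains open.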